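This account rests on a few compounds, and the source may have more. Where it says the series, first, only, none or still open, it means among the compounds named here.

The series shares one core, seen in compound 1 `COc1cccc(N2C(=O)CS/C2=N\c2csc(-c3ccc(Cl)cc3)c2)c1`, compound 2 `O=C1CS/C(=N\c2csc(-c3ccc(Cl)cc3)c2)N1c1ccc(Cl)cc1`, compound 3 `O=C1CS/C(=N\c2csc(-c3ccc(Cl)cc3)c2)N1c1ccccc1` and the unmeasured compound 4 `Cc1ccc(N2C(=O)CS/C2=N\c2csc(-c3ccc(Cl)cc3)c2)cc1`. In a functional assay on SW-620 cells (Homo sapiens) for cytotoxicity, read by MTT assay, with a stated time of 72 h (on this read-out higher numbers stand for weaker inhibition and lower numbers for stronger inhibition), compound 1 gives 33000 nM. For compound 2 the result is a limit of the assay, > 50000 nM. For compound 3 no number exists; in this assay compound 3 stands at "not determined" (no result reported), so its place among the others is open. Among the compounds with values here, the one measured step, an at least 1.5-fold higher number from compound 1 to compound 2 (0.18 log units; that floor lies within the scatter), is a change on the same ring nitrogen and sits against the limit (the limit of > 50000 nM in this assay, at which 1 of the 3 values shown sits). The change to compound 4 is methyl in place of hydrogen on an aromatic carbon. Within the data shown here, with no number for compound 3 and only one small step nearby, compound 4 is expected to be weak, at an estimated 40000 nM, within 15000 nM to 100000 nM.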

Compound 4, half-maximal inhibitory concentration: > 50000 nM
Compound 4: no number, only a limit; the forecaster's own chance of this, stated with the estimate: 45%; middle value at least 1.2-fold (0.09 log units) from the limit.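

In this assay, compound 4 gives only a limit, and so with a 4-methylphenyl group on the ring nitrogen it joins compound 2 rather than yielding a number. Placing 4-methylphenyl in place of 3-methoxyphenyl gives an at least 1.5-fold higher number from compound 1 to compound 4 (0.18 log units; that floor lies within the scatter). The step from compound 2 to compound 4 cannot be read, since both results are limits, and the series now gathers there: the limit of > 50000 nM in this assay, at which 2 of the 4 values shown sit.

From the compounds shown here alone, with no number for compound 3, the effect of methyl in place of hydrogen remains unknown. Going by these compounds, whether an amine or a carboxylic acid at this place would give a readable number also stays open.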